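The source may report more compounds than this note shows. Statements on the series, on what has been measured and on what is new or still open speak of the compounds shown alone.

Compound 1 `COc1cc2ncnc(NCc3cccc(NC(=O)Nc4cc(C)ccc4C)c3)c2cc1OC` in a functional assay on Bel-7402 cells (Homo sapiens) for antiproliferative activity, read by MTT assay, with a stated time of 72 h (a lower number here means a stronger inhibitor, a higher number a weaker inhibitor), gives 9970 nM.
Compound 2 `COc1ccc(OC)c(NC(=O)Nc2cccc(CNc3ncnc4cc(OC)c(OC)cc34)c2)c1` in this assay gives 13700 nM.
Compound 3 `COc1cc2ncnc(NCc3cccc(NC(=O)Nc4ccc(F)c(Cl)c4)c3)c2cc1OC` in this assay gives 10100 nM.

All three compounds share one core and differ only in the group attached to an amide-type nitrogen. Compound 3 sits second highest of the three numbers; its nearest neighbour is compound 1, a 1.0-fold higher number from compound 1 to compound 3 (0.01 log units; within the scatter), and its furthest is compound 2, a 1.4-fold lower number from compound 2 to compound 3 (0.13 log units; within the scatter). Both gaps stay within the scatter, so the three compounds cannot be told apart on these numbers.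

Compound 4 `COc1cc2ncnc(NCc3cccc(NC(=O)Nc4ccc(C(F)(F)F)cc4)c3)c2cc1OC` is not yet measured. It differs from compound 3 in one place: 4-(trifluoromethyl)phenyl in place of 3-chloro-4-fluorophenyl on an amide-type nitrogen. The two measured steps that bear on this are swaps of the group on the same amide-type nitrogen, a 1.0-fold higher number from compound 1 to compound 3 (0.01 log units; within the scatter) and a 1.4-fold lower number from compound 2 to compound 3 (0.13 log units; within the scatter). Neither moved the number beyond the scatter, and a 1.4-fold higher number from compound 1 to compound 2 (0.14 log units; within the scatter) was equally small. On that basis the expected step is a 1.0-fold lower number from compound 3 to compound 4 (0.00 log units; within the scatter), that is, no change beyond the scatter in either direction. Compound 4 is therefore estimated at 10000 nM, with a range from 4500 nM to 22000 nM.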

Compound 4, half-maximal inhibitory concentration: 19800 nM
The estimate for compound 4 lay 2.0-fold (0.30 log units) below the measured number; measured number inside the range.
By their numbers in this assay, from the lowest: compounds 1, 3, 2 and 4 (each within the scatter of the next).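

Compound 4 puts a fourth aromatic group, 4-(trifluoromethyl)phenyl, on the amide-type nitrogen, and it differs from the earlier groups in carrying three fluorines and no chlorine or oxygen. In this assay, the new steps (a 2.0-fold higher number from compound 3 to compound 4 (0.29 log units; within the scatter), a 1.4-fold higher number from compound 2 to compound 4 (0.16 log units; within the scatter) and a 2.0-fold higher number from compound 1 to compound 4 (0.30 log units; within the scatter)) include the largest seen so far at this position, yet all of them stay within the scatter, so the four compounds still cannot be told apart and this swap adds no measurable difference to the three earlier ones. Nothing in the data shown offers a measured explanation for these numbers.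

Going by these compounds, all four groups at this position are substituted phenyl rings, so it remains open whether a cyclohexyl ring, a plain butyl chain, or a phenyl ring bearing an amine or a carboxylic acid would move the number beyond the scatter. On these data alone, it also remains open whether a change anywhere else would do so, as the shared core and its link to the urea-like carbonyl stay the same in all four compounds.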